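This account rests on a few compounds, and the source may have more. Where it says the series, first, only, none or still open, it means among the compounds named here.

In a functional assay on ileum (Cavia porcellus) for antagonist activity, with a stated time of 30 s (on this read-out lower numbers stand for stronger inhibition and higher numbers for weaker inhibition), compound 2 `O=C(O)c1cc(=O)c2ccc(OCCCOc3ccccc3)cc2o1` gives 1.4 ug/mL and compound 3 `O=C(O)c1cc(=O)c2ccc(OCCCCCCCCCOc3ccccc3)cc2o1` gives 1.8 ug/mL, the two lying within the scatter of each other. Compound 1 `O=C(O)c1cc(=O)c2ccc(OCCOc3ccccc3)cc2o1` gives 15 ug/mL.

Compound 4 `O=C(O)c1cc(=O)c2ccc(OCCCCCSc3ccccc3)cc2o1` is not yet measured. It differs from compound 2 by 2-(phenylsulfanyl)ethyl in place of phenoxy on a saturated chain carbon, three bonds along the chain from an oxygen on an aromatic ring, with 2-(phenylsulfanyl)ethyl in place of phenoxy on a saturated chain carbon, three bonds along the chain from an oxygen on an aromatic ring.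

Going by the values given here, the only measured step on this chain, phenoxymethyl in place of phenoxy, is an 11-fold lower number from compound 1 to compound 2 (1.03 log units; beyond the scatter), which is large and beyond the scatter. It starts from the shortest chain, so it bears only weakly here. Compound 3 bears more directly: its chain is longer than that of compound 4, yet compound 3 at 1.8 ug/mL stays within the scatter of compound 2. Among the compounds with values here, no measured step covers sulfur in place of the phenoxy oxygen, so the range stays wide.

No change beyond the scatter is expected in this assay, and no direction is favoured. The expected step is a 1.1-fold higher number from compound 2 to compound 4 (0.06 log units; within the scatter). For compound 4 the estimated value is 1.6 ug/mL, with an expected range from 0.6 ug/mL to 4.5 ug/mL.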

Compound 4, half-maximal inhibitory concentration: 0.4 ug/mL
Compound 4: the middle estimate sits 4.0-fold (0.60 log units) above what was measured, and the stated range ends above it.
By their numbers in this assay, from the lowest: compound 4; then compounds 2 and 3 (each within the scatter of the next); then compound 1.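

In this assay, 2-(phenylsulfanyl)ethyl in place of phenoxy on a saturated chain carbon, three bonds along the chain from an oxygen on an aromatic ring, gives a 3.5-fold lower number from compound 2 to compound 4 (0.54 log units; beyond the scatter). Compound 3, whose chain also ends in phenoxy, lies within the scatter of compound 2, so among the compounds shown, a number below that level at this place appears only with the sulfur-containing group. No measurement here accounts for the step.

The change lengthens the chain and puts sulfur in place of the phenoxy oxygen at once, so the share of each cannot be read from these compounds. A phenoxy group on a chain of the same length, and an amine or a sulfonyl group in place of the sulfur, would bear on that question.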